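Hydroxy to methoxy on compound 2

A few compounds are considered here, and "the series" means these few. Any claim that something is new, unique, unknown or untested is made for them only; others in the source may bear on it.

In a functional assay on PC-3 cells (Homo sapiens) for cytotoxicity (a lower number here means a stronger inhibitor, a higher number a weaker inhibitor), compound 2 `Oc1cccc(/C=N/n2cnnc2)c1O` gives > 30000 nM as a limit of the assay, not a number. Compound 1 `COc1cccc(/C=N/c2nnc[nH]2)c1O` gives > 30000 nM as a limit too. Going by the values given here, the series thus stands at the limit of > 30000 nM in this assay, at which 2 of the 2 values shown sit, and offers no measured step. Compound 3 `COc1cccc(/C=N/n2cnnc2)c1O` has methyl in place of hydrogen on an oxygen on an aromatic ring, hydroxy to methoxy (methyl in place of hydrogen on an oxygen on an aromatic ring). In this assay the expected step of a number no higher from compound 2 to compound 3 (the limit leaves the size open) is estimated as none beyond the scatter, with no direction favoured. For compound 3 the estimate is 30000 nM with an expected range from 12000 nM to 60000 nM in this read-out.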

Compound 3, half-maximal inhibitory concentration: > 30000 nM
Compound 3 ended at the assay's limit; the forecaster's own chance of this, stated with the estimate: 75%; the middle value lies on the limit itself.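

Compound 1, compound 2 and compound 3 all sit at a limit in this assay, so no step among them can be read: the limit of > 30000 nM in this assay, at which 3 of the 3 values shown sit.

The compounds shown leave open whether either change on the shared core alters potency at all.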